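Aryl variation on the arylidene arm of compound 1

The source may hold more compounds than are shown below. What is called first, only, known or untested is meant among the compounds shown, and "the series" means these compounds.

Compound 1 `COc1ccc(/C=C2/SC(N3CCC[C@H]3C(=O)Nc3ccc4ncnc(Nc5cccc(Cl)c5)c4c3)=NC2=O)cc1` carries a 4-methoxyphenyl on the double-bonded chain carbon bound to a double-bonded ring carbon. In a functional assay on A549 cells (Homo sapiens) for antiproliferative activity, read by MTT assay (a lower number here means a stronger inhibitor, a higher number a weaker inhibitor), compound 1 gives 31700 nM, the highest of the three numbers recorded so far. Compound 2 `Cc1cccc(/C=C2/SC(N3CCC[C@H]3C(=O)Nc3ccc4ncnc(Nc5cccc(Cl)c5)c4c3)=NC2=O)n1` gives 8500 nM and compound 3 `O=C1N=C(N2CCC[C@H]2C(=O)Nc2ccc3ncnc(Nc4cccc(Cl)c4)c3c2)S/C1=C/c1cccnc1Cl` gives 10800 nM; these two stand within the scatter of each other, a 1.3-fold higher number from compound 2 to compound 3 (0.10 log units; within the scatter). Both replacements of the 4-methoxyphenyl lowered the number: a 3.7-fold lower number from compound 1 to compound 2 (0.57 log units; beyond the scatter) and a 2.9-fold lower number from compound 1 to compound 3 (0.47 log units; beyond the scatter).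

Compound 4 `O=C1N=C(N2CCC[C@H]2C(=O)Nc2ccc3ncnc(Nc4cccc(Cl)c4)c3c2)S/C1=C/c1ccccc1[N+](=O)[O-]` is the next variant at the same place: 2-nitrophenyl in place of 4-methoxyphenyl on a double-bonded chain carbon bound to a double-bonded ring carbon. The two steps that bear on it, from compound 1 to compound 2 and from compound 1 to compound 3, are both modest lowerings beyond the scatter, so a lowering of similar size is expected for compound 4, though a 2-nitrophenyl has not been tried in this series and the step could also end within the scatter. For compound 4 in this assay the estimate is 12000 nM, with a range from 5000 nM to 35000 nM, which would mean an expected step of a 2.6-fold lower number from compound 1 to compound 4 (0.42 log units; beyond the scatter).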

Compound 4, half-maximal inhibitory concentration: > 50000 nM
Compound 4: a limit, no number; the forecaster's own chance of this, stated with the estimate: 10%; at least 4.1-fold (0.61 log units) between middle value and limit.
By their numbers in this assay, from the lowest: compounds 2 and 3 (each within the scatter of the next); then compound 1. At a limit, above all of these: compound 4.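

In this assay compound 4 gives > 50000 nM which is a limit of the assay and not a number. Replacing either pyridinyl group with 2-nitrophenyl gives an at least 4.6-fold higher number from compound 3 to compound 4 (0.66 log units; beyond the scatter) and an at least 5.8-fold higher number from compound 2 to compound 4 (0.76 log units; beyond the scatter) so a change at this place on the double-bonded chain carbon can raise the number as well as lower it. The step of an at least 1.5-fold higher number from compound 1 to compound 4 (0.19 log units; that floor lies within the scatter) does not by itself separate these two. None of the lowering seen with compounds 2 and 3 appears in this step.

As far as these compounds go, the true value of compound 4 stays open, and with it the full size of all three steps. Also open, from the compounds shown here alone, is whether a 2-aminophenyl, with an amine in place of the nitro group, would fall with compounds 2 and 3 or with compound 4.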